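Working notes: from compound 3 to compound 4

The compounds below may be only part of what the source reports. "The series", "measured", "known", "first", "only" and "open" are said of these compounds alone.

Compound 1 `COC(=O)c1ccc(NCc2cncn2Cc2cccc([N+](=O)[O-])c2)cc1-c1ccccc1`: > 10000 nM, a limit
Compound 2 `COC(=O)c1ccc(NCc2cncn2Cc2ccccc2Cl)cc1-c1ccccc1`: 10000 nM
Compound 3 `COC(=O)c1ccc(NCc2cncn2Cc2ccc([N+](=O)[O-])cc2)cc1-c1ccccc1`: > 10000 nM, a limit

All three compounds were read in a toxicity assay on NIH3T3 cells (Mus musculus) for cytotoxicity, read by resazurin assay; a lower number here means that less compound is needed, a higher number that more compound is needed for the effect. Compound 3 gives > 10000 nM, which is a limit and not a number. The set as a whole is marked by the limit of > 10000 nM in this assay, at which 2 of the 3 values shown sit.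

Compound 4 `COC(=O)c1ccc(NCc2cncn2Cc2cccc(F)c2)cc1-c1ccccc1` carries 3-fluorophenyl in place of 4-nitrophenyl on a saturated chain carbon bound to an aromatic nitrogen.

Three measured steps change this same group, and none has a readable size: a number no higher from compound 1 to compound 2 (the limit leaves the size open), a step that the two limits leave unreadable from compound 1 to compound 3 and a number no lower from compound 2 to compound 3 (the limit leaves the size open). For the measured compounds named here, no compound with a fluorine has been measured yet. Going by the values given here, the only plain number is that of compound 2, at 10000 nM, and the expectation for the new compound rests on it.

The expected change is no step beyond the scatter, and the estimated step is a step that the limit leaves unreadable from compound 3 to compound 4. For compound 4 the estimated value is 12000 nM, with an expected range from 6000 nM to 30000 nM.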

Compound 4, half-maximal effective concentration: > 1000 nM
Compound 4 ended at the assay's limit; the forecaster's own chance of this, stated with the estimate: 70%; the middle value does not contradict the limit.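

Compound 4 gives > 1000 nM, which is a limit. No new step can be read from it: its steps from compound 1, compound 2 and compound 3 all stay unreadable. Going by these compounds, still open in this assay is whether 3-fluorophenyl, 2-chlorophenyl and the two nitrophenyl groups differ at all.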